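The compounds below may be only part of what the source reports. "The series", "measured", "known", "first", "only" and "open" are said of these compounds alone.

In an ADME assay on L929 cells (Mus musculus) for cytotoxicity, read by resazurin assay, with a stated time of 48 h (on this read-out higher numbers stand for lower toxicity in this test and lower numbers for higher toxicity in this test), compound 3 `COC(=O)Cn1c2ccc([N+](=O)[O-])cc2c(=O)n1Cc1ccccc1` gives 129000 nM, compound 1 `C=CCn1c2ccc([N+](=O)[O-])cc2c(=O)n1Cc1ccccc1` gives 192000 nM and compound 2 `O=c1c2cc([N+](=O)[O-])ccc2n(CCCBr)n1Cc1ccccc1` gives 25200 nM. Compound 3 thus stands within the scatter of compound 1 and clear of compound 2 at the low end. Compound 4 `COC(=O)CCn1c2ccc([N+](=O)[O-])cc2c(=O)n1Cc1ccccc1` follows from compound 3 by one change: (methoxycarbonyl)methyl in place of methoxycarbonyl on a saturated chain carbon bound to an aromatic nitrogen. The nearest guide is a 1.5-fold lower number from compound 1 to compound 3 (0.17 log units; within the scatter). The larger moves, a 7.6-fold lower number from compound 1 to compound 2 (0.88 log units; beyond the scatter) and a 5.1-fold higher number from compound 2 to compound 3 (0.71 log units; beyond the scatter), both involve the 2-bromoethyl group, which compound 4 lacks. No step beyond the scatter is therefore expected in this assay, in either direction. The estimated step is a 1.1-fold lower number from compound 3 to compound 4 (0.03 log units; within the scatter). Compound 4 is expected at 120000 nM, within an estimated range of 60000 nM to 230000 nM.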

Compound 4, concentration lethal to 50% of the cells: > 256000 nM
Compound 4: a limit, no number; the forecaster's own chance of this, stated with the estimate: 5%; middle value at least 2.1-fold (0.32 log units) from the limit.
By their numbers in this assay, from the lowest: compound 2; then compounds 3 and 1 (each within the scatter of the next). At a limit, above all of these: compound 4.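

In this assay compound 4 gives a limit of the assay, not a number: the limit of > 256000 nM in this assay, at which 1 of the 4 values shown sits. Going from methoxycarbonyl to (methoxycarbonyl)methyl on a saturated chain carbon bound to an aromatic nitrogen brings no fall in the number: an at least 1.9-fold higher number from compound 3 to compound 4 (0.29 log units; that floor lies within the scatter) and an at least 1.3-fold higher number from compound 1 to compound 4 (0.12 log units; that floor lies within the scatter) establish no rise either, as both floors lie within the scatter. Only an at least 10-fold higher number from compound 2 to compound 4 (1.00 log units; beyond the scatter) clears the scatter, so the separation from the bromo-bearing chain of compound 2 now also holds for the longer methoxycarbonyl chain. From the compounds shown here alone, the true value of compound 4 stays open. So does whether a carboxylic acid, an amine or a still longer chain at this place would keep the number this high.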